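This account rests on a few compounds, and the source may have more. Where it says the series, first, only, none or still open, it means among the compounds named here.

Measured compounds:
- compound 1, `COc1ccc(S(=O)(=O)N2CC(C(=O)N3CC(CN)C3)c3ccccc32)c2ccccc12`: in a functional assay on CHO cells for antagonist activity at 5-hydroxytryptamine receptor 6 (Homo sapiens), read by FLIPR (a lower number here means a stronger inhibitor, a higher number a weaker inhibitor), compound 1 gives 79.4 nM
- compound 2, `COc1ccc(S(=O)(=O)N2CC(C(=O)N3CCNCC3)c3ccccc32)c2ccccc12`: compound 2 gives 7.94 nM
- compound 3, `CCN(CC)CCNC(=O)C1CN(S(=O)(=O)c2ccc(OC)c3ccccc23)c2ccccc21`: compound 3 gives 20 nM

Compound 3 holds the middle place of the three: its number is beyond the scatter above that of compound 2 and beyond the scatter below that of compound 1, as the steps of a 2.5-fold higher number from compound 2 to compound 3 (0.40 log units; beyond the scatter) and a 4.0-fold lower number from compound 1 to compound 3 (0.60 log units; beyond the scatter) show. Compound 4, `CCN(CC)CCCNC(=O)C1CN(S(=O)(=O)c2ccc(OC)c3ccccc23)c2ccccc21`, keeps the shared core and the amide of compound 3 and differs only in the chain: (diethylamino)methyl in place of diethylamino on a saturated chain carbon, two bonds along the chain from an amide-type nitrogen. Among the compounds with values here, none of the measured steps, a 10-fold lower number from compound 1 to compound 2 (1.00 log units; beyond the scatter), a 4.0-fold lower number from compound 1 to compound 3 (0.60 log units; beyond the scatter) or a 2.5-fold higher number from compound 2 to compound 3 (0.40 log units; beyond the scatter), lengthens a chain; each swaps one amine-bearing group for another, and all three stay modest. A change of one chain carbon within the same group is therefore expected to move this assay less than those swaps did, and no change at the digits printed from compound 3 to compound 4 (within the scatter) is the expected step, inside the scatter. Compound 4 is estimated at 20 nM, with a range from 7 nM to 55 nM.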

Compound 4, inhibition constant: 79.4 nM
Beside the measured number, compound 4's estimate is 4.0-fold (0.60 log units) below it, and the stated range ends below it.
By their numbers in this assay, from the lowest: compound 2; then compound 3; then compounds 1 and 4 (each within the scatter of the next).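

In this assay, lengthening 2-(diethylamino)ethyl to 3-(diethylamino)propyl gives a 4.0-fold higher number from compound 3 to compound 4 (0.60 log units; beyond the scatter) and so shows that this chain, on a saturated carbon two bonds along from an amide-type nitrogen, does not tolerate the change without a shift beyond the scatter. The longer chain also widens the gap to the piperazin-1-yl amide, with a 10-fold higher number from compound 2 to compound 4 (1.00 log units; beyond the scatter) as the step, while no change at the digits printed from compound 1 to compound 4 (within the scatter) removes the advantage that the shorter chain had held over the 3-(aminomethyl)azetidin-1-yl amide. Nothing among the data shown accounts for this shift.

The compounds shown leave open whether a still longer chain, such as 4-(diethylamino)butyl, would continue the same trend. They also leave open how dimethylamino or pyrrolidin-1-yl in place of diethylamino would fare on either chain.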